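Two Biphenyl Substituents Compared in a Cyclopropane Amide Series

A few compounds are considered here, and "the series" means these few. Any claim that something is new, unique, unknown or untested is made for them only; others in the source may bear on it.

Of the compounds shown here, three of one series have been measured in a functional assay for agonist activity at G protein-coupled receptor 88 (Homo sapiens), read by HTRF and cAMP accumulation; on this read-out higher numbers stand for an effect only at larger amounts of compound and lower numbers for an effect already at smaller amounts. Compound 1 `CO[C@H](C)[C@H](N)CN(C(=O)[C@@H]1C[C@H]1c1ccccc1)c1ccc(-c2ccccc2)cc1` gives 0.68 nM in this assay. Compound 2 `CC[C@H](C)[C@H](N)CN(C(=O)[C@@H]1C[C@H]1c1ccc(F)cc1)c1ccc(-c2ccccc2)cc1` gives 600 nM. Compound 3 `Cc1cccc(-c2ccc(N(C[C@@H](N)CC(C)C)C(=O)[C@@H]3C[C@H]3c3ccccc3)cc2)c1` gives 1200 nM, the highest of the three numbers; its nearest neighbour is compound 2, whose number lies within the usual scatter of that of compound 3, while compound 1 stands far lower, well beyond the scatter.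

Compound 4 `CC(C)C[C@H](N)CN(C(=O)[C@@H]1C[C@H]1c1ccccc1)c1ccc(-c2ccccc2Cl)cc1` has not yet been measured in this assay. It differs from compound 3 in one place: 2-chlorophenyl in place of 3-methylphenyl on an aromatic carbon. Going by the values given here, no pair of measured compounds differs only at this position, so the data give no direct guide to the size of this step, and the chain and the remaining parts of the core are unchanged.

The step from compound 3 to compound 4 is expected to be a 3.0-fold lower number from compound 3 to compound 4 (0.48 log units; beyond the scatter), a modest move that may or may not exceed the scatter. For compound 4 the estimated value in this assay is 400 nM, with a likely range from 80 nM to 2000 nM.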

Compound 4, half-maximal effective concentration: 3800 nM
Beside the measured number, compound 4's estimate is 9.5-fold (0.98 log units) below it; the whole stated range lies below it.
By their numbers in this assay, from the lowest: compound 1; then compounds 2 and 3 (each within the scatter of the next); then compound 4.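

In this assay, going by these compounds alone, 2-chlorophenyl in place of 3-methylphenyl, on an aromatic carbon para to a large group, gives a 3.2-fold higher number from compound 3 to compound 4 (0.50 log units; beyond the scatter), the first step at this position that can be read. The two groups match in heavy-atom count and in their counts of hydrogen-bond donors and acceptors, yet the number still moves beyond the scatter, so this position responds to a change that those counts do not register. Nothing measured on these groups bears on the result, and it offers no explanation for the step.

The compounds shown leave open whether the step follows the chlorine itself or its place on the ring, as one pair cannot separate the two. Going by these compounds, how a nitrile, a methoxy group or a carboxylic acid on this ring would read also stays open, as does whether the step holds with the chain of compound 1.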